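Benzyl ether ring substitution and tolerated concentration, compound 4

A few compounds are considered here, and "the series" means these few. Any claim that something is new, unique, unknown or untested is made for them only; others in the source may bear on it.

Compound 1 `N#Cc1ccc(Nc2nccc(OCc3ccccc3Cl)n2)cc1` stands second highest of the three numbers in an ADME assay on MT4 cells (Homo sapiens) for cytotoxicity, read by MTT assay, with a stated time of 5 days (a higher number here means that more compound is tolerated, a lower number that less compound is tolerated), where compound 1 gives 146000 nM. Compound 3 `N#Cc1ccc(Nc2nccc(OCc3ccccc3F)n2)cc1` lies within the scatter of it: compound 3 gives 151000 nM, the step being a 1.0-fold higher number from compound 1 to compound 3 (0.01 log units; within the scatter). Compound 2 `N#Cc1ccc(Nc2nccc(OCc3ccc(Br)cc3)n2)cc1` gives 16000 nM, a step of a 9.1-fold lower number from compound 1 to compound 2 (0.96 log units; beyond the scatter); in the same sense the step of a 9.4-fold higher number from compound 2 to compound 3 (0.97 log units; beyond the scatter) separates the 4-bromophenyl compound from the 2-fluorophenyl one.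

Compound 4 `Cc1cccc(COc2ccnc(Nc3ccc(C#N)cc3)n2)c1` remains to be measured in this assay. Relative to compound 1 the change is 3-methylphenyl in place of 2-chlorophenyl on a saturated chain carbon bound to an oxygen on an aromatic ring. Among the measured compounds shown here, no measured step exchanges a 2-chlorophenyl for a 3-methylphenyl, so the bearing is indirect: the step of a 1.0-fold higher number from compound 1 to compound 3 (0.01 log units; within the scatter) shows that swapping one halogen for another on the same ring leaves the number unchanged, whereas a 9.1-fold lower number from compound 1 to compound 2 (0.96 log units; beyond the scatter) shows that a differently substituted phenyl on the saturated chain carbon can lower the number beyond the scatter. A 3-methylphenyl is neither case, and a modest downward step is expected, a 2.4-fold lower number from compound 1 to compound 4 (0.39 log units; beyond the scatter), with a wide range. Compound 4 is estimated at 60000 nM, expected between 15000 nM and 200000 nM.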

Compound 4, half-maximal cytotoxic concentration: 30000 nM
Estimate against measurement, compound 4: 2.0-fold (0.30 log units) above; measured number inside the range.
By their numbers in this assay, from the lowest: compounds 2 and 4 (each within the scatter of the next); then compounds 1 and 3 (each within the scatter of the next).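

In this assay, the lower number is not confined to the 4-bromophenyl: a halogen-free 3-methylphenyl also gives a 4.9-fold lower number from compound 1 to compound 4 (0.69 log units; beyond the scatter) and a 5.0-fold lower number from compound 3 to compound 4 (0.70 log units; beyond the scatter), while a 1.9-fold higher number from compound 2 to compound 4 (0.27 log units; within the scatter) places it level with the bromo compound. Across these four compounds the series splits into two tiers, with the 2-chlorophenyl and 2-fluorophenyl compounds 1 and 3 together at the higher numbers and compounds 2 and 4 together at the lower numbers, and no compound goes against this split. No measurement shown gives a reason for this split.

Compounds 2 and 4 differ from compounds 1 and 3 in both the substituent and its place on the ring, so these two factors cannot be separated here. An unsubstituted phenyl would give a reference point that is still missing from this set.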